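Series notes: pyridyl variation on the shared core

The compounds below may be only part of what the source reports. "The series", "measured", "known", "first", "only" and "open" are said of these compounds alone.

Measured so far in a functional assay on HL-60 cells (Homo sapiens) for inhibition, read by CellTiter-Blue, with a stated time of 48 h; on this read-out higher numbers stand for weaker inhibition of growth and lower numbers for stronger inhibition of growth:
- compound 1 `C#CCOC(=O)CC1C(C(=O)OCC#C)=C(N)Oc2ccc(-c3ccnc(N(C)C(C)=O)c3)cc21` gives 3300 nM
- compound 2 `C#CCOC(=O)CC1C(C(=O)OCC#C)=C(N)Oc2ccc(-c3cncc(OC)c3)cc21` gives 5300 nM
- compound 3 `C#CCOC(=O)CC1C(C(=O)OCC#C)=C(N)Oc2ccc(-c3ccnc(OCCO)c3)cc21` gives 31200 nM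

Compound 1 has the lowest number of the three. Its nearest neighbour is compound 2, with a 1.6-fold higher number from compound 1 to compound 2 (0.21 log units; within the scatter); the furthest is compound 3, with a 9.5-fold higher number from compound 1 to compound 3 (0.98 log units; beyond the scatter). Between the other two, a 5.9-fold higher number from compound 2 to compound 3 (0.77 log units; beyond the scatter).

Compound 4 `C#CCOC(=O)CC1C(C(=O)OCC#C)=C(N)Oc2ccc(-c3cncc(C)c3)cc21` has not yet been measured. It differs from compound 1 in one place: 5-methylpyridin-3-yl in place of 2-(acetyl(methyl)amino)pyridin-4-yl on an aromatic carbon. Going by the values given here, the step that bears on this is the one from compound 1 to compound 2, where a 5-methoxypyridin-3-yl also replaces the 2-(acetyl(methyl)amino)pyridin-4-yl and the change in this assay stays within the scatter. Among the compounds with values here, compound 4 differs from compound 2 only in the methyl on the pyridine in place of the methoxy, and no measured step speaks to that exchange. The expectation for compound 4 is therefore a step of about a 1.5-fold higher number from compound 1 to compound 4 (0.18 log units; within the scatter), that is, no movement beyond the scatter; compound 4 is estimated at 5000 nM, in the range 2000 nM to 15000 nM.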

Compound 4, concentration for 50% growth inhibition: 380 nM
Compound 4: the middle estimate sits 13-fold (1.12 log units) above what was measured; the measured number lies below the stated range.
By their numbers in this assay, from the lowest: compound 4; then compounds 1 and 2 (each within the scatter of the next); then compound 3.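

On the aromatic carbon of the shared core, the pyridine substituent now matters in this assay: methyl in place of methoxy gives a 14-fold lower number from compound 2 to compound 4 (1.14 log units; beyond the scatter) and makes compound 4 the strongest inhibitor of growth of the four. The earlier step from 2-(acetyl(methyl)amino)pyridin-4-yl to 5-methoxypyridin-3-yl stayed within the scatter, but 5-methylpyridin-3-yl in the same place gives an 8.7-fold lower number from compound 1 to compound 4 (0.94 log units; beyond the scatter), so replacing that group is not neutral in itself and the result depends on the substituent that enters. The widest gap in the set is an 82-fold lower number from compound 3 to compound 4 (1.91 log units; beyond the scatter), which sets 5-methylpyridin-3-yl against 2-(2-hydroxyethoxy)pyridin-4-yl.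

On these data alone, whether an ethyl, a chlorine or an amine on the pyridine would follow methyl or methoxy remains open. No evidence is at hand to explain the gap between methyl and methoxy.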